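A fluoro added at the assay limit

This account rests on a few compounds, and the source may have more. Where it says the series, first, only, none or still open, it means among the compounds named here.

In a functional assay on RAW264.7 cells (Mus musculus) for inhibition, with stated times of 2 h and 24 h (on this read-out lower numbers stand for stronger inhibition and higher numbers for weaker inhibition), compound 1 `COc1ccc([C@@H]2c3c(OC)cc(OC)cc3C(SCc3ccc(C)cc3)[C@H]2c2cc(OC)cc(OC)c2)cc1` gives > 200000 nM, which is a limit. Compound 2 `COc1ccc([C@@H]2c3c(OC)cc(OC)cc3C(SCc3ccc(F)cc3)[C@H]2c2cc(OC)cc(OC)c2)cc1` gives > 200000 nM, also a limit. Compound 3 `COc1ccc([C@@H]2c3c(OC)cc(OC)cc3C(C(O)c3ccccc3)[C@H]2c2cc(OC)cc(OC)c2)cc1` gives > 200000 nM, again a limit, so it has no exact number. All three sit at the limit of > 200000 nM in this assay, at which 3 of the 3 values shown sit.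

Compound 4 `COc1ccc([C@@H]2c3c(OC)cc(OC)cc3C(C(O)c3ccc(F)cc3)[C@H]2c2cc(OC)cc(OC)c2)cc1` differs from compound 3 by one change: fluoro in place of hydrogen on an aromatic carbon, para to a large group. The closest measured change is a step that the two limits leave unreadable from compound 1 to compound 2, which also places fluoro on an aromatic carbon. The other is a step that the two limits leave unreadable from compound 2 to compound 3. Neither has a readable size, so no step beyond the scatter is expected in this assay.

The expected change is a number no higher from compound 3 to compound 4 (the limit leaves the size open). Compound 4 is estimated at 200000 nM, within an expected range of 70000 nM to 300000 nM.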

Compound 4, half-maximal inhibitory concentration: > 200000 nM
Compound 4 was reported as a limit (the forecaster's own chance of this, stated with the estimate: 85%); the middle value sits exactly at the limit.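

Compound 4 also gives only a limit, so no step can be read between it and compound 1, compound 2 or compound 3: the limit of > 200000 nM in this assay, at which 4 of the 4 values shown sit.

The compounds shown leave open what structural change, if any, would bring a measurable value.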